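This account rests on a few compounds, and the source may have more. Where it says the series, first, only, none or still open, it means among the compounds named here.

Measured so far:
Compound 1 `CN1CCC[C@@H]1Cn1nc(Cc2ccc(F)cc2)c2ccccc2c1=O` — in an assay for binding affinity to Alpha-1A adrenergic receptor (Homo sapiens) (on this read-out higher numbers stand for weaker inhibition and lower numbers for stronger inhibition), compound 1 gives 63.1 nM.
Compound 2 `COc1cccc(Cc2nn(C[C@H]3CCCN3C)c(=O)c3ccccc23)c1` — in this assay compound 2 gives 1580 nM.

For the measured compounds named here, compound 2 stands at the highest of the two numbers, and the only step measured so far leads to it: a 25-fold higher number from compound 1 to compound 2 (1.40 log units; beyond the scatter). Compound 3 `CCCCCc1nn(C[C@H]2CCCN2C)c(=O)c2ccccc12` is not yet measured. It differs from compound 2 in one place: butyl in place of 3-methoxyphenyl on a saturated chain carbon bound to an aromatic carbon. Going by the values given here, no measured step changes the group on this saturated chain carbon in the way the step to compound 3 does; the step from compound 1 to compound 2 exchanges one aromatic group for another, and so bears on it only loosely, showing that this place is sensitive to change. Among the compounds with values here, with no direct precedent, the direction is uncertain, and a step within or just beyond the scatter in either direction in this assay seems plausible. Compound 3 is therefore estimated at 1200 nM, within 250 nM to 6000 nM, a step of a 1.3-fold lower number from compound 2 to compound 3 (0.12 log units; within the scatter).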

Compound 3, inhibition constant: 501 nM
Compound 3: middle estimate off by 2.4-fold (0.38 log units), on the high side; low and high end bracket the measured number.
By their numbers in this assay, from the lowest: compound 1; then compound 3; then compound 2.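

In this assay, the aromatic ring at this place on a saturated chain carbon bound to an aromatic carbon proves not to be required for a lower number: butyl in place of 3-methoxyphenyl gives a 3.2-fold lower number from compound 2 to compound 3 (0.50 log units; beyond the scatter) and this lies beyond the scatter. The ring's absence does not match 4-fluorophenyl, however, since the same exchange made on compound 1 gives a 7.9-fold higher number from compound 1 to compound 3 (0.90 log units; beyond the scatter) and so the open chain of compound 3 sits between the two aromatic groups. Nothing in hand explains this order.

The compounds shown leave open whether a longer chain, a shorter chain or a chain ending in an amine or a carboxylic acid would move the number further. They also leave open how unsubstituted phenyl would compare with 4-fluorophenyl and 3-methoxyphenyl.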